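The source may report more compounds than this note shows. Statements on the series, on what has been measured and on what is new or still open speak of the compounds shown alone.

Measured so far in this study:
compound 1, `O=C(Nc1ccc(Sc2nc3ccccc3s2)cc1)c1cc(Br)cc(Br)c1`: > 100000 nM
compound 2, `COc1c(Br)cccc1C(=O)Nc1ccc(Sc2nc3ccccc3s2)cc1`: > 100000 nM
compound 3, `O=C(Nc1ccc(Sc2nc3ccccc3s2)cc1)c1cccc(Br)c1`: > 100000 nM

In an assay on isolated protein for inhibition of thiosulfate sulfurtransferase (Homo sapiens), with a stated time of 60 min, in the absence of a further agent (on this read-out higher numbers stand for weaker inhibition and lower numbers for stronger inhibition), compound 3 gives no number, only a limit of the assay, > 100000 nM. Compound 1 likewise gives only a limit of this assay. Compound 2 also gives only a limit of this assay. This is summed up by the limit of > 100000 nM in this assay, at which 3 of the 3 values shown sit. The measured steps a step that the two limits leave unreadable from compound 1 to compound 2, a step that the two limits leave unreadable from compound 1 to compound 3 and a step that the two limits leave unreadable from compound 2 to compound 3 are therefore all unreadable in size and direction, and none of them tells how far any of the three compounds lies beyond the limit.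

Compound 4, `O=C(Nc1ccc(Sc2nc3ccccc3s2)cc1)c1cc(Br)ccc1O`, differs from compound 3 by hydroxy in place of hydrogen on an aromatic carbon. Among the measured compounds shown here, no measured step bears on this change in a readable way; the three limits leave the size of the step in this assay open in both directions. On the numbers shown, compound 4 is expected to give about 100000 nM, with a range from 20000 nM to 300000 nM. The step from compound 3 to compound 4 is thus estimated at a number no higher from compound 3 to compound 4 (the limit leaves the size open), most probably again ending at a limit rather than a number.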

Compound 4, half-maximal inhibitory concentration: > 100000 nM
Compound 4 was reported as a limit (the forecaster's own chance of this, stated with the estimate: 70%); the middle value lies on the limit itself.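

Compound 4 joins compound 1, compound 2 and compound 3 as a limit in this assay, so no step to compound 4 can be read in size or direction: the limit of > 100000 nM in this assay, at which 4 of the 4 values shown sit.

Going by these compounds, how far compound 1, compound 2, compound 3 and compound 4 each lie beyond that limit stays open, as does whether any group on the carbonyl carbon of the shared core would give a measurable number.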